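Thiazole acetic acid series: aryl exchange from compound 2

The compounds below may be only part of what the source reports. "The series", "measured", "known", "first", "only" and "open" are said of these compounds alone.

Measured compounds and their values in an in vitro functional assay on HEK285-7 cells for antagonist activity at prostaglandin D2 receptor 2 (Homo sapiens), read by BRET and beta-arrestin recruitment; a lower number here means a stronger inhibitor, a higher number a weaker inhibitor:
- compound 1 `Cc1nc(-c2ccc(Cl)cc2)c(CC(=O)O)s1`: 41000 nM
- compound 2 `O=C(O)Cc1sc(C(c2ccc(F)cc2)c2ccc(F)cc2)nc1-c1ccco1`: 140 nM

Compound 2 has the lowest of the two numbers recorded so far. For the measured compounds named here, its nearest neighbour is compound 1, whose number is higher by a margin well beyond the scatter, so the two are clearly separated; no single-point step between them is available, and what the pair shows is only that compound 2 is the stronger inhibitor of the two.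

Compound 3 `O=C(O)Cc1sc(C(c2ccc(F)cc2)c2ccc(F)cc2)nc1-c1ccnc(N2CCCC2)c1` has not yet been measured. Compared with compound 2 the change is 2-(pyrrolidin-1-yl)pyridin-4-yl in place of furan-2-yl on an aromatic carbon. The carboxymethyl group and the large group on the shared core are left as they are; only the aromatic substituent on the ring carbon described above is exchanged.

Without a measured step for this kind of exchange, the expectation for compound 3 is a number near that of compound 2, with a step of a 1.3-fold lower number from compound 2 to compound 3 (0.10 log units; within the scatter) that is expected to stay within the scatter, in either direction. The estimate for compound 3 in this assay is 110 nM, with a range from 20 nM to 600 nM.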

Compound 3, half-maximal inhibitory concentration: > 100000 nM
Compound 3: no number, only a limit; the forecaster's own chance of this, stated with the estimate: 2%; middle value at least 900-fold (2.95 log units) away from the limit.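

In this assay the position on the aromatic carbon next to the ring nitrogen proves far from tolerant of exchange, with the carboxymethyl group and the large group left as they are: an at least 710-fold higher number from compound 2 to compound 3 (2.85 log units; beyond the scatter). For the compounds shown here, compound 3 gives > 100000 nM, which is a limit of the assay and not a number, so the step can be read only as a bound and its true size stays unknown: the limit of > 100000 nM in this assay, at which 1 of the 3 values shown sits. Compound 1 and compound 2 differ in more than one place and could tie no change in number to any single position, so this step is the first to show that this position alone can separate a compound with a measurable number from one at the limit.

The exchange brings in a six-membered aromatic ring, its ring nitrogen and a pyrrolidine all at once, and the compounds shown do not tell which of these parts accounts for the step. Open, going by these compounds, is whether phenyl or unsubstituted pyridin-4-yl at this position, or a dimethylamino group in place of the pyrrolidine, would keep a number close to that of compound 2.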